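The compounds below may be only part of what the source reports. "The series", "measured", "known", "first", "only" and "open" are said of these compounds alone.

Measured so far:
Compound 1, `CS/C(=N\C(=O)c1sccc1Cl)NC(=O)c1sccc1Cl`, in a functional assay on K562 cells (Homo sapiens) for cytotoxicity, read by MTT assay, with a stated time of 72 h (on this read-out lower numbers stand for higher toxicity in this test and higher numbers for lower toxicity in this test), gives > 100000 nM, which is a limit of the assay and not a number.
Compound 2, `C[Se]/C(=N\C(=O)c1cccs1)NC(=O)c1cccs1`, in this assay gives > 100000 nM, again only a limit.

Compound 1 therefore stands at the limit of > 100000 nM in this assay, at which 2 of the 2 values shown sit, and compound 2 stops at the same limit, so neither compound can be placed relative to the other. Compound 3, `C[Se]/C(=N\C(=O)c1sccc1Cl)NC(=O)c1sccc1Cl`, has not yet been tested in this assay. It differs from compound 1 by a group of 2 heavy atoms (1 carbon, 1 selenium; no ring) in place of a group of 2 heavy atoms (1 carbon, 1 sulfur; no ring), on a carbon with a double bond to nitrogen. Among the compounds with values here, no measured step connects compound 1 with compound 3, and nothing among the values shown points in either direction. The expected step from compound 1 to compound 3 is none beyond the scatter, a number no higher from compound 1 to compound 3 (the limit leaves the size open). For compound 3 the estimate in this assay is 100000 nM, with a range from 30000 nM to 1000000 nM, and most likely the assay will again report only a limit.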

Compound 3, concentration lethal to 50% of the cells: 90000 nM
Estimate against measurement, compound 3: 1.1-fold (0.05 log units) above; low and high end bracket the measured number.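

In this assay, replacing the methylsulfanyl group with its selenium counterpart, on a carbon with a double bond to nitrogen, gives the first result at this position that is a real number and not a limit: compound 3 gives 90000 nM. Going by these compounds, the change reads as an at least 1.1-fold lower number from compound 1 to compound 3 (0.04 log units; that floor lies within the scatter); compound 1 stops at a limit, so this is only the smallest step the data allow, and the true size of the swap stays unknown. The new number also sits close to the top of the range this test can report, and the other results still stop at its ceiling: the limit of > 100000 nM in this assay, at which 2 of the 3 values shown sit.

The compounds shown leave open how a longer chain or an amine on that same carbon would read in this assay, which would show whether this position can carry anything that moves the number clearly. Compound 2 also has no sulfur partner among the compounds shown, so it remains open whether the swap from sulfur to selenium would read the same way on its core.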